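Replacing oxan-4-yl with 1-acetylpiperidin-4-yl in compound 3

The compounds below may be only part of what the source reports. "The series", "measured", "known", "first", "only" and "open" are said of these compounds alone.

Of the compounds shown here, three sharing one core have been measured so far in an ADME assay (liver, Mus musculus) for metabolic stability, using microsomes (a lower number here means that the compound disappears faster, a higher number that the compound lasts longer), and they span a modest range. Compound 1 `C=CC(=O)Nc1cccc(CNc2nc(Nc3cn(C)nc3C)ncc2Cl)c1` gives 0.138 h and compound 2 `C=CC(=O)Nc1cccc(CNc2nc(Nc3cnn(C(F)F)c3)ncc2Cl)c1` gives 0.173 h on this measure, while compound 3 `C=CC(=O)Nc1cccc(CNc2nc(Nc3cnn(C4CCOCC4)c3)ncc2Cl)c1` gives 0.025 h and holds the lowest number of the three.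

Compound 4 `C=CC(=O)Nc1cccc(CNc2nc(Nc3cnn(C4CCN(C(C)=O)CC4)c3)ncc2Cl)c1` differs from compound 3 in one place, with 1-acetylpiperidin-4-yl in place of oxan-4-yl on an aromatic nitrogen as the full count of the change. Among the measured compounds shown here, two measured steps bear on it. The closer one is a 6.9-fold lower number from compound 2 to compound 3 (0.84 log units; beyond the scatter) and it was made on the same aromatic nitrogen, so a change at this place can move the number beyond the scatter. The other, a 1.3-fold higher number from compound 1 to compound 2 (0.10 log units; within the scatter), stayed within the scatter. For the measured compounds named here, neither step tests the present swap, since both groups carry one six-membered non-aromatic ring with 1 hetero atom and no measured compound carries 1-acetylpiperidin-4-yl.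

Going by the values given here, a smaller step than the one into compound 3 therefore seems likely. The expected move is a 1.6-fold higher number from compound 3 to compound 4 (0.20 log units; within the scatter) and its slight upward lean is only an expectation. The estimated value for compound 4 is 0.04 h (range 0.015 h to 0.11 h).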

Compound 4, half-life: 0.05 h
Estimate against measurement, compound 4: 1.3-fold (0.10 log units) below, within the range that was stated.
By their numbers in this assay, from the lowest: compounds 3 and 4 (each within the scatter of the next); then compounds 1 and 2 (each within the scatter of the next).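

In this assay the aromatic nitrogen now carries a second group built on a six-membered non-aromatic ring with 1 hetero atom, and 1-acetylpiperidin-4-yl in place of oxan-4-yl gives a 2.0-fold higher number from compound 3 to compound 4 (0.30 log units; within the scatter), so exchanging the ring oxygen for an acetylated ring nitrogen does not separate these two compounds beyond the scatter. The comparison with the small group on the same nitrogen also holds for this new ring, with a 3.5-fold lower number from compound 2 to compound 4 (0.54 log units; beyond the scatter), which means that among the compounds shown both ring-bearing groups, oxan-4-yl and 1-acetylpiperidin-4-yl, stand on the same side of difluoromethyl and beyond the scatter from it. Nothing available gives a reason for this result.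

As far as these compounds go, it remains open whether a piperidin-4-yl ring with a free amine in place of the acetyl, or a ring bearing a carboxylic acid, would stay with compound 3 and compound 4 or come closer to compound 2. From the compounds shown here alone, it is equally open whether an open chain such as a methoxyethyl group on the same nitrogen would behave like the rings or like difluoromethyl.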